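This account rests on a few compounds, and the source may have more. Where it says the series, first, only, none or still open, it means among the compounds named here.

Among the measured compounds shown here, in a functional assay on HT-29 cells (Homo sapiens) for cytotoxicity, read by MTT assay, with a stated time of 72 h (on this read-out higher numbers stand for weaker inhibition and lower numbers for stronger inhibition), compound 2 `CN(C)CCn1cnnc1-c1cc(Oc2ccc(NC(=O)N/N=C/c3ccc(O)c(F)c3)cc2F)ccn1` gives 3310 nM, the highest of the two numbers measured so far. For the measured compounds named here, the only other compound measured, compound 1 `CN(C)CCn1cnnc1-c1cc(Oc2ccc(NC(=O)N/N=C/c3ccccc3O[N+](=O)[O-])cc2F)ccn1`, gives 950 nM in this assay. Going by the values given here, the one measured step, a 3.5-fold higher number from compound 1 to compound 2 (0.54 log units; beyond the scatter), exchanges the whole ring group on the carbon with a double bond to nitrogen. Compound 3 `COc1cc(/C=N/NC(=O)Nc2ccc(Oc3ccnc(-c4nncn4CCN(C)C)c3)c(F)c2)ccc1O` differs from compound 2 by a smaller change: methoxy in place of fluoro on an aromatic carbon. Among the compounds with values here, no measured step tests this exchange itself; the step from compound 1 to compound 2 shows only that reshaping this ring group can move the number beyond the scatter. With so little to go on, the number for compound 3 is expected to change little from that of compound 2, giving an estimated step of a 1.3-fold lower number from compound 2 to compound 3 (0.12 log units; within the scatter). The estimate for compound 3 is therefore 2500 nM, within a range from 900 nM to 7000 nM.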

Compound 3, half-maximal inhibitory concentration: 120 nM
Compound 3: middle estimate off by 21-fold (1.32 log units), on the high side; measured number below the stated range.
By their numbers in this assay, from the lowest: compound 3; then compound 1; then compound 2.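

In this assay, this position on the ring carrying the hydroxy group proves highly sensitive: methoxy in place of fluoro, ortho to a hydroxy group, adds only one heavy atom yet gives a large step (a 28-fold lower number from compound 2 to compound 3 (1.44 log units; beyond the scatter)), bigger than the exchange of the whole ring group seen earlier (a 3.5-fold higher number from compound 1 to compound 2 (0.54 log units; beyond the scatter)). The 4-hydroxy-3-methoxyphenyl group also improves on the 2-(nitrooxy)phenyl group (a 7.9-fold lower number from compound 1 to compound 3 (0.90 log units; beyond the scatter)), so compound 3 has the lowest number of the three, with both of its steps beyond the scatter. Nothing available explains the size of this change.

From the compounds shown here alone, only fluoro and methoxy can be compared at this place, so it remains open whether an ethoxy group, a chlorine atom or an amine there would behave like either one. Going by these compounds, the hydroxy group's share in the drop also remains open, since fluoro and methoxy both sit ortho to it.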